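The compounds below may be only part of what the source reports. "The series", "measured", "known", "first", "only" and "open" are said of these compounds alone.

Measured so far in an ADME assay on A549 cells (Homo sapiens) for cytotoxicity, read by CellTiter-Glo; a lower number here means that less compound is tolerated, a higher number that more compound is tolerated:
Compound 1 `Cc1c(Cc2ccc(C(C)(C)C)cc2)c(=O)oc2cc(OCC(O)CN3CCC(C(N)=O)CC3)ccc12`: 14700 nM
Compound 2 `COc1ccc(Cc2c(C)c3ccc(OCC(O)CN4CCC(C(N)=O)CC4)cc3oc2=O)c(Br)c1`: 44400 nM
Compound 3 `Cc1c(Cc2ccc(C(F)(F)F)cc2)c(=O)oc2cc(OCC(O)CN3CCC(C(N)=O)CC3)ccc12`: 89300 nM

All three share one core and differ only in the group carried on the benzyl arm. Among the three numbers, compound 3 gives the highest, meaning the most compound is tolerated by the cells; the step of a 6.1-fold higher number from compound 1 to compound 3 (0.78 log units; beyond the scatter) lies beyond the scatter, but the step of a 2.0-fold higher number from compound 2 to compound 3 (0.30 log units; within the scatter) does not, so compound 2 and compound 3 cannot be told apart on this measure.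

Compound 4 `Cc1c(Cc2ccc(OC(F)(F)F)cc2)c(=O)oc2cc(OCC(O)CN3CCC(C(N)=O)CC3)ccc12` has not yet been measured. Compared with compound 3 the change is trifluoromethoxy in place of trifluoromethyl on an aromatic carbon, para to a large group.

Within the data shown here, no measured step swaps exactly these two groups. Among the measured compounds shown here, the steps that bear on the question are a 6.1-fold higher number from compound 1 to compound 3 (0.78 log units; beyond the scatter) and a 3.0-fold higher number from compound 1 to compound 2 (0.48 log units; beyond the scatter), both modest, and a 2.0-fold higher number from compound 2 to compound 3 (0.30 log units; within the scatter), within the scatter: exchanging one group for another on this arm has so far shifted the number only moderately, and the smallest of these exchanges did not move it beyond the scatter. A small change in one atom and one acceptor is therefore expected to leave the number close to that of compound 3, with no step beyond the scatter in this assay in either direction.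

Compound 4 is expected to give about 75000 nM, in the range 30000 nM to 180000 nM. That estimate corresponds to an expected step of a 1.2-fold lower number from compound 3 to compound 4 (0.08 log units; within the scatter), within the scatter.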

Compound 4, half-maximal cytotoxic concentration: 68200 nM
Compound 4: the middle estimate sits 1.1-fold (0.04 log units) above what was measured; the measured number falls inside the stated range.
By their numbers in this assay, from the lowest: compound 1; then compounds 2, 4 and 3 (each within the scatter of the next).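

In this assay, putting trifluoromethoxy in place of trifluoromethyl on an aromatic carbon, para to a large group, gives a 1.3-fold lower number from compound 3 to compound 4 (0.12 log units; within the scatter), so adding this one oxygen atom, which brings one hydrogen-bond acceptor with it, does not separate the two compounds on this measure. Compound 4 also cannot be told apart from the compound carrying the 2-bromo-4-methoxyphenyl group, with a 1.5-fold higher number from compound 2 to compound 4 (0.19 log units; within the scatter), while the tert-butyl compound remains set apart, with a 4.6-fold higher number from compound 1 to compound 4 (0.67 log units; beyond the scatter), and this makes compound 1 the only one of the four whose steps to all the others lie beyond the scatter. Nothing available here explains why these groups give the numbers they do.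

The compounds shown leave open what happens when this para place on the benzyl arm carries an amine, a carboxylic acid or a nitrile, as all of the groups compared so far are uncharged. They also leave open whether trifluoromethoxy and trifluoromethyl would still match on another carbon of that aromatic ring, or with a different chain joining the arm to the shared core.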